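A few compounds are considered here, and "the series" means these few. Any claim that something is new, unique, unknown or untested is made for them only; others in the source may bear on it.

In a functional assay on MCF7 cells (Homo sapiens) for antiproliferative activity (a higher number here means a weaker inhibitor, a lower number a stronger inhibitor), compound 1 `O=C(Nc1ccc(O)c2c(=O)cc(-c3ccccc3Cl)oc12)c1ccccc1` gives 7100 nM and compound 2 `O=C(Nc1ccc(O)c2c(=O)cc(-c3ccccc3Cl)oc12)c1ccc(Cl)cc1` gives 4600 nM while compound 3 `O=C(Nc1ccc(O)c2c(=O)cc(-c3ccccc3Cl)oc12)c1ccc(Cl)c(Cl)c1` gives 15000 nM as the highest number of the three and so the weakest result. The change to compound 4 `Cc1ccc(C(=O)Nc2ccc(O)c3c(=O)cc(-c4ccccc4Cl)oc23)cc1` is 4-methylphenyl in place of 3,4-dichlorophenyl on a carbonyl carbon and it removes the 3,4-dichlorophenyl on a carbonyl carbon. For the measured compounds named here, three measured steps bear on it: a 2.1-fold higher number from compound 1 to compound 3 (0.32 log units; beyond the scatter) and a 3.3-fold higher number from compound 2 to compound 3 (0.51 log units; beyond the scatter) are both modest and beyond the scatter, whereas a 1.5-fold lower number from compound 1 to compound 2 (0.19 log units; within the scatter) stays within it. Going by the values given here, no measured compound carries the 4-methylphenyl, so the expectation remains uncertain. The expected change in this assay is modest, a 2.5-fold lower number from compound 3 to compound 4 (0.40 log units; beyond the scatter) by this estimate. For compound 4 the estimated value is 6000 nM with a range from 2500 nM to 13000 nM as the expected span.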

Compound 4, half-maximal inhibitory concentration: 10000 nM
Compound 4: the middle estimate sits 1.7-fold (0.22 log units) below what was measured; low and high end bracket the measured number.
By their numbers in this assay, from the lowest: compounds 2, 1, 4 and 3 (each within the scatter of the next, the first and the last beyond it).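

In this assay, the 4-methylphenyl on the carbonyl carbon cannot be told apart from the 3,4-dichlorophenyl, with a 1.5-fold lower number from compound 3 to compound 4 (0.18 log units; within the scatter), or from the phenyl, with a 1.4-fold higher number from compound 1 to compound 4 (0.15 log units; within the scatter). Only the single chloro separates from it, since methyl in place of chloro gives a 2.2-fold higher number from compound 2 to compound 4 (0.34 log units; beyond the scatter), so methyl and chloro are not interchangeable here. Nothing available explains this difference. Going by these compounds, what an amine or a carboxylic acid in place of the methyl of compound 4 would give stays open, as does the effect of a longer chain there.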